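Removing one trifluoromethyl from the urea tail

A few compounds are considered here, and "the series" means these few. Any claim that something is new, unique, unknown or untested is made for them only; others in the source may bear on it.

Compound 2 `COc1cc(Cl)cc(-c2nn(-c3cccc(NC(=O)Nc4cc(C(F)(F)F)cc(C(F)(F)F)c4)c3)cc2-c2ccncc2)c1`: 370 nM
Compound 1 `O=C(Nc1cccc(-n2cc(-c3ccncc3)c(-c3cc(O)cc(Cl)c3)n2)c1)Nc1ccc(Cl)c(C(F)(F)F)c1`: 2330 nM

Of the compounds shown here, two with the same core have been measured in a functional assay on A549 cells (Homo sapiens) for inhibition, read by sulforhodamine B assay, with a stated time of 48 h; a lower number here means a stronger inhibitor, a higher number a weaker inhibitor. Compound 2 gives the lower of the two numbers; compound 1 gives a number that is higher by a margin beyond the usual scatter, so compound 2 is the stronger inhibitor of the two. Compound 1 and compound 2 differ in more than one place, so no single change can be read from that gap.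

Compound 3 `COc1cc(Cl)cc(-c2nn(-c3cccc(NC(=O)Nc4cccc(C(F)(F)F)c4)c3)cc2-c2ccncc2)c1` has not yet been measured in this assay. It differs from compound 2 in one place: hydrogen in place of trifluoromethyl on an aromatic carbon. Among the compounds with values here, with no measured pair that isolates this change, the size of the step is uncertain. Because compound 2 gives 370 nM and loses a group of the urea tail that compound 1 also carries, a modest loss of potency is expected rather than a gain. The step from compound 2 to compound 3 is estimated as a 2.4-fold higher number from compound 2 to compound 3 (0.39 log units; beyond the scatter). Compound 3 is therefore expected to give 900 nM, within a range of 300 nM to 2700 nM.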

Compound 3, half-maximal inhibitory concentration: 730 nM
For compound 3 the middle estimate is 1.2-fold (0.09 log units) above the measured one; measured number inside the range.
By their numbers in this assay, from the lowest: compounds 2 and 3 (each within the scatter of the next); then compound 1.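

Within the data shown here, the first pair here that differs in one place only gives a direct reading of this position: in this assay, hydrogen in place of trifluoromethyl on an aromatic carbon gives a 2.0-fold higher number from compound 2 to compound 3 (0.30 log units; within the scatter). On this reading, a urea tail with one trifluoromethyl and a urea tail with two cannot be told apart in this assay, so the second group, with its 4 heavy atoms, is not shown to matter for the number. No measurement shown here offers an explanation for this result.

What the compounds shown leave open is how much this aromatic carbon tolerates beyond these two cases: a methyl, a nitrile, an amine or a carboxylic acid in the same place could give a number close to these or far from them. The remaining trifluoromethyl also has no one-place partner here, so a tail with no trifluoromethyl at all, carrying only hydrogen on these carbons, would be needed to show what that group contributes.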